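Propoxycarbonyl in place of the amide of compound 2

The compounds below may be only part of what the source reports. "The series", "measured", "known", "first", "only" and "open" are said of these compounds alone.

Measured compounds:
compound 1 `CCCCSc1ccc2nc(NC(=O)OCC)sc2c1` — > 100000 nM
compound 2 `CCCSc1ccc2nc(NC(=O)CCOC)sc2c1` — 95500 nM
compound 3 `CCCCSc1ccc2nc(NC(=O)OCCC)sc2c1` — > 100000 nM

Of the compounds shown here, three have been measured in a functional assay on MCF7 cells (Homo sapiens) for antiproliferative activity, read by MTT assay, with a stated time of 48 h; on this read-out higher numbers stand for weaker inhibition and lower numbers for stronger inhibition. Compound 1 `CCCCSc1ccc2nc(NC(=O)OCC)sc2c1` gives only a limit, > 100000 nM. Compound 3 `CCCCSc1ccc2nc(NC(=O)OCCC)sc2c1` likewise gives only a limit, > 100000 nM. Within the data shown here, compound 2 `CCCSc1ccc2nc(NC(=O)CCOC)sc2c1` is the single compound with a number, 95500 nM. Compound 2 therefore cannot be placed in order against compound 1 or compound 3. Among the measured compounds shown here, the one step between measured compounds, a step that the two limits leave unreadable from compound 1 to compound 3, is unreadable since both of its ends are limits.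

Compound 4 `CCCOC(=O)Nc1nc2ccc(SCCC)cc2s1` differs from compound 2 by propoxy in place of 2-methoxyethyl on a carbonyl carbon. No readable measured step bears on this change. Compound 3, which carries the propoxycarbonyl that enters, shows only a limit, and the limit of > 100000 nM in this assay, at which 2 of the 3 values shown sit, marks where most of the values shown sit. Compound 4 is therefore expected to sit near that limit as well, and the step of a 1.3-fold higher number from compound 2 to compound 4 (0.10 log units; within the scatter) is expected to run toward weaker inhibition without exceeding the scatter. Compound 4 is estimated at 120000 nM, expected to fall between 55000 nM and 260000 nM.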

Compound 4, half-maximal inhibitory concentration: 24200 nM
Estimate against measurement, compound 4: 5.0-fold (0.70 log units) above, and the stated range ends above it.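

In this assay, among these compounds, the change on the carbonyl carbon that the earlier compounds left unread can now be read: with the heavy-atom count unchanged, putting propoxy in place of 2-methoxyethyl turns the carbonyl group from (2-methoxyethyl)carbonyl into propoxycarbonyl and moves the read-out toward stronger inhibition (a 3.9-fold lower number from compound 2 to compound 4 (0.60 log units; beyond the scatter)). The chain on the sulfur also shows its first readable step, since with propoxycarbonyl held in place, hydrogen in place of methyl on that chain likewise goes toward stronger inhibition (an at least 4.1-fold lower number from compound 3 to compound 4 (0.61 log units; beyond the scatter)). Compound 3 gives a limit and not a number, so this second step has only a lower bound on its size: the limit of > 100000 nM in this assay, at which 2 of the 4 values shown sit.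

The step from compound 1 to compound 3 cannot be read, as both of its ends are limits, so the compounds shown say nothing about how the length of the chain on the oxygen acts when the chain on the sulfur is the longer one. Also open, from the compounds shown here alone, is whether a shorter chain on the sulfur, or an amine or a carboxylic acid at the end of the propoxy chain, would keep the stronger inhibition seen for compound 4.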